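Moving Trifluoromethyl to Another Aromatic Carbon

This account rests on a few compounds, and the source may have more. Where it says the series, first, only, none or still open, it means among the compounds named here.

Compound 1 `CC(C(=O)N1CCN(c2ccccc2)CC1)N1C(=O)CCC1=O` was tested in a functional assay on the whole organism (strain Swiss) with Mus musculus as the target, in the maximal electroshock model, with a stated time of 0.25 h, at a dose of 300 mg/kg by the intraperitoneal route (on this read-out higher numbers stand for a stronger effect at the one dose given and lower numbers for a weaker effect), where compound 1 gives 100%. Compound 3 `CC(C(=O)N1CCN(c2ccc(F)cc2)CC1)N1C(=O)CCC1=O` gives 100% in this assay, and compound 2 `CC(C(=O)N1CCN(c2ccc(C(F)(F)F)cc2)CC1)N1C(=O)CCC1=O` gives 25%. Compound 1 thus stands level with compound 3, the two together being the highest of the three numbers, since no change at the digits printed from compound 1 to compound 3 (within the scatter); its furthest neighbour is compound 2, as a number 75 percentage points lower from compound 1 to compound 2 (beyond the scatter). Compound 4 `CC(C(=O)N1CCN(c2cccc(C(F)(F)F)c2)CC1)N1C(=O)CCC1=O` has not yet been measured. It differs from compound 1 by trifluoromethyl in place of hydrogen on an aromatic carbon. For the measured compounds named here, the steps that bear on it are those in which the same group enters or leaves at a different aromatic carbon: a number 75 percentage points lower from compound 1 to compound 2 (beyond the scatter) and a number 75 percentage points higher from compound 2 to compound 3 (beyond the scatter). Wherever trifluoromethyl has been present among the measured compounds, the read-out was far lower. Whether this carries over to the new aromatic carbon cannot be settled from three compounds, so the uncertainty is wide. A fall beyond the scatter is nonetheless expected, and compound 4 is estimated at 50% with a range of 10% to 100%, an expected step of a number 50 percentage points lower from compound 1 to compound 4 (beyond the scatter).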

Compound 4, a percentage reported as activity, at one dose (the size of the read-out at that dose, not a potency): 75%
Estimate against measurement, compound 4: 25 percentage points below; the range from low to high includes it.
By their numbers in this assay, from the lowest: compound 2; then compound 4; then compounds 1 and 3 (each within the scatter of the next).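

In this assay the step at this aromatic carbon is a number 25 percentage points lower from compound 1 to compound 4 (beyond the scatter) and is modest, so placing trifluoromethyl meta to a large group still lowers the read-out, as it did in compound 2. The position of the group also goes with a different number on the same core: with trifluoromethyl on its own aromatic carbon compound 2 gives 25%, while compound 4 gives 75% at the carbon examined here. Nothing on hand explains why the two carbons give different numbers.

The compounds shown leave open whether a smaller group on this carbon, such as fluoro, methyl or chloro, would stay level with compound 1, and what an amine or a methoxy group would do there. They also leave open how compound 4 behaves at other doses and times, since the read-out covers a single dose and a single time.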